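Heteroaryl swap at the shared core: pyrimidine for thiazole

The source may report more compounds than this note shows. Statements on the series, on what has been measured and on what is new or still open speak of the compounds shown alone.

Three compounds share one core and differ only in the heteroaryl attached to it. Compound 1 `Fc1ccc2nc(-c3cnco3)n(C3CC3)c2c1` in an assay on cells for inhibition of cytochrome P450 11B2, mitochondrial (Homo sapiens), read by HPLC, with a stated time of 90 min (a higher number here means a weaker inhibitor, a lower number a stronger inhibitor), gives only a limit, > 10000 nM. Compound 2 `Fc1ccc2nc(-c3cn[nH]c3)n(C3CC3)c2c1` gives 782 nM in this assay. Compound 3 `Fc1ccc2nc(-c3cncs3)n(C3CC3)c2c1` gives 62 nM in this assay, the lowest of the two numbers; its nearest neighbour is compound 2, and the step of a 13-fold lower number from compound 2 to compound 3 (1.10 log units; beyond the scatter) is beyond the scatter. The two steps from compound 1 are at least as large: an at least 12-fold lower number from compound 1 to compound 2 (1.10 log units; beyond the scatter) and an at least 160-fold lower number from compound 1 to compound 3 (2.20 log units; beyond the scatter), both resting on the limit (the limit of > 10000 nM in this assay, at which 1 of the 3 values shown sits).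

Compound 4 `Fc1ccc2nc(-c3cncnc3)n(C3CC3)c2c1` differs from compound 3 by pyrimidin-5-yl in place of 1,3-thiazol-5-yl on an aromatic carbon. Going by the values given here, no measured step exchanges a five-membered heteroaryl for a six-membered one, so none bears directly on this change; the three measured steps show only that exchanging the heteroaryl moves this assay by large amounts, so a step beyond the scatter is plausible while its direction is not fixed by the data. Compound 4 is expected to give a somewhat higher number than compound 3, a step of a 2.4-fold higher number from compound 3 to compound 4 (0.38 log units; beyond the scatter). The estimate for compound 4 in this assay is 150 nM, within 40 nM to 800 nM.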

Compound 4, half-maximal inhibitory concentration: 40 nM
Beside the measured number, compound 4's estimate is 3.8-fold (0.57 log units) above it; measured number inside the range.
By their numbers in this assay, from the lowest: compounds 4 and 3 (each within the scatter of the next); then compound 2. At a limit, above all of these: compound 1.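

At this position, ring size alone does not set the outcome: in this assay, the exchange of a five-membered for a six-membered heteroaryl gives a 1.6-fold lower number from compound 3 to compound 4 (0.19 log units; within the scatter), so pyrimidin-5-yl and 1,3-thiazol-5-yl cannot be told apart here. The six-membered ring also matches the gain that 1,3-thiazol-5-yl showed over 1H-pyrazol-4-yl, with a 20-fold lower number from compound 2 to compound 4 (1.29 log units; beyond the scatter). The step of an at least 250-fold lower number from compound 1 to compound 4 (2.39 log units; beyond the scatter) gives only a minimum size, and it rests on the limit for compound 1: the limit of > 10000 nM in this assay, at which 1 of the 4 values shown sits.

Open, going by these compounds, is whether the ring nitrogen atoms of pyrimidin-5-yl are needed at all: a pyridin-3-yl or a plain phenyl group on this carbon would test that. Also open, on these data alone, is whether these values hold with a longer alkyl chain in place of the cyclopropyl group.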